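The source may report more compounds than this note shows. Statements on the series, on what has been measured and on what is new or still open speak of the compounds shown alone.

Measured so far:
compound 1 `CCCOC(=O)C1=C(C)NC(=O)NC1c1cccs1` — 43%
compound 2 `CC1=C(C(=O)OC2CCC2)C(c2ccoc2)NC(=O)N1` — 20%

In an assay on membranes from CHO cells for displacement of a labelled ligand from adenosine receptor A1 (Homo sapiens), read by scintillation counting, with a stated time of 60 min, tested at 1 uM (a higher number here means more inhibition at the concentration tested (going by the name of the read-out), a lower number less inhibition), compound 1 gives 43% and compound 2 gives 20%. Compound 2 stands lowest of the two numbers, and its gap to compound 1 lies beyond the scatter of this assay. Compound 3 `CC1=C(C(=O)OC2CCC2)C(c2cccs2)NC(=O)N1` has not yet been measured in this assay. It differs from compound 2 in one place: thiophen-2-yl in place of furan-3-yl on a saturated ring carbon. For the measured compounds named here, no step between two measured compounds covers this change alone, since compound 1 and compound 2 also differ in their ester group. Still, compound 3 now carries the same thiophen-2-yl as compound 1, so an upward step of moderate size is expected, a number 12 percentage points higher from compound 2 to compound 3 (beyond the scatter), because compound 1 gives 43%. Compound 3 is thus estimated at 32%, within a range from 15% to 50%.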

Compound 3, a percentage reported as inhibition, at one concentration (the size of the read-out at that concentration, not a potency): 24%
Compound 3: the middle estimate sits 8 percentage points above what was measured, and the stated range covers the measured number.
By their numbers in this assay, from the lowest: compounds 2 and 3 (each within the scatter of the next); then compound 1.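

In this assay, with cyclobutyl held fixed on the ester, thiophen-2-yl in place of furan-3-yl on the saturated ring carbon gives a number 4 percentage points higher from compound 2 to compound 3 (within the scatter), so among these compounds the exchange of one five-membered aromatic ring for the other leaves no readable mark at this position. With thiophen-2-yl held fixed, cyclobutyl in place of propyl on an oxygen next to a carbonyl group gives a number 19 percentage points lower from compound 1 to compound 3 (beyond the scatter), so the gap seen earlier between compound 1 and compound 2 now tracks the ester group and not the aromatic ring. Nothing measured here explains either step.

As far as these compounds go, whether the two aromatic rings also match when propyl sits on the ester remains open. How phenyl on the saturated ring carbon, or a longer chain on the ester oxygen, would read in this assay is open too.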